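Permeability notes on the oxazole-piperidine amide series

The source may hold more compounds than are shown below. What is called first, only, known or untested is meant among the compounds shown, and "the series" means these compounds.

For the measured compounds named here, compound 1 `Cc1oc(-c2c(C)c(C)c(C)c(C)c2C)nc1CN1CCC(C(=O)NCCCN2C[C@H](C)C[C@H](C)C2)CC1` is the only member of the series with a number in a physicochemical assay for permeability, using PAMPA; on this read-out higher numbers stand for higher permeability and lower numbers for lower permeability; compound 1 gives 455 10^-6 cm/s. Compound 2 `Cc1oc(-c2c(Cl)cccc2Cl)nc1CN1CCC(C(=O)NCCCN2C[C@H](C)C[C@H](C)C2)CC1` is recorded in this assay as "not determined" (no result reported), and compound 3 `Cc1oc(-c2c(Cl)cccc2C(F)(F)F)nc1CN1CCC(C(=O)NCCCN2C[C@H](C)C[C@H](C)C2)CC1` is recorded in this assay as "not determined" (no result reported), so compound 3 stands without a number and without any step to a measured neighbour. The change from compound 3 to compound 4 `COc1cccc(C)c1-c1nc(CN2CCC(C(=O)NCCCN3C[C@H](C)C[C@H](C)C3)CC2)c(C)o1` is 2-methoxy-6-methylphenyl in place of 2-chloro-6-(trifluoromethyl)phenyl on an aromatic carbon. Because compound 3 has no value, no size or direction of the step can be computed, and nothing in the set of measured numbers indicates a shift beyond the usual scatter of this assay for an exchange of this kind on the aryl ring of the shared core. Going by the values given here, the only anchor is compound 1, whose reading in this assay of 455 10^-6 cm/s sits high. On that basis compound 4 is expected to give 350 10^-6 cm/s in this assay, estimated between 150 10^-6 cm/s and 700 10^-6 cm/s.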

Compound 4, apparent permeability: 198 10^-6 cm/s
The estimate for compound 4 lay 1.8-fold (0.25 log units) above the measured number; measured number inside the range.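

For the compounds shown here, the exchange of 2,3,4,5,6-pentamethylphenyl for 2-methoxy-6-methylphenyl gives a 2.3-fold lower number from compound 1 to compound 4 (0.36 log units; beyond the scatter) and is the first readable step at this position, showing that this assay responds beyond the usual scatter to a change in the aryl group on the shared core. The steps that involve compound 2 or compound 3 cannot be read, so this one comparison rests on compound 1 alone. No measured property of these compounds accounts for the step.

Going by these compounds alone, the single exchange brings in the methoxy group and removes methyl groups together, so the share of each in the step stays open. Also open, from the compounds shown here alone, is how this assay would read with an unsubstituted phenyl, or with an amine or a carboxylic acid on the aryl ring, in this position.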